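Polyamine chain extension on two chalcone cores

This account rests on a few compounds, and the source may have more. Where it says the series, first, only, none or still open, it means among the compounds named here.

Compound 3 `COc1ccc(/C=C/C(=O)c2cc(OC)c(OC)c(OC)c2)cc1OCCCC(=O)NCCCCNCCCN` and compound 1 `COc1ccc(/C=C/C(=O)c2cc(OC)c(OC)c(OC)c2)cc1OCCCC(=O)NCCCCN(CCCN)CCCCNCCCN` share one core and differ by a single change, (4-((3-aminopropyl)amino)butyl in place of hydrogen on an amine nitrogen). In a functional assay on HT-29 cells (Homo sapiens) for antiproliferative activity, read by MTT assay, with a stated time of 48 h (on this read-out lower numbers stand for stronger inhibition and higher numbers for weaker inhibition), compound 3 reaches only > 100000 nM, which is a limit of the assay and not a number. In this assay compound 1 gives 89100 nM. The step of an at least 1.1-fold lower number from compound 3 to compound 1 (0.05 log units; that floor lies within the scatter) lies within the scatter, so the two values cannot be ordered. Compound 2 `COc1cc(C(=O)/C=C/c2ccc(OCCCC(=O)NCCCCNCCCN)cc2)cc(OC)c1OC` carries the second core; the difference between the two cores is not broken down here. In this assay compound 2 sits at > 100000 nM, again a limit and not a number, a point underlined by the limit of > 100000 nM in this assay, at which 2 of the 3 values shown sit. Compound 4 `COc1cc(C(=O)/C=C/c2ccc(OCCCC(=O)NCCCCN(CCCN)CCCCNCCCN)cc2)cc(OC)c1OC` has not been measured; it differs from compound 2 by 4-((3-aminopropyl)amino)butyl in place of hydrogen on an amine nitrogen, the same change that separates compound 3 from compound 1. Since that change moved compound 3 to compound 1 by only an at least 1.1-fold lower number from compound 3 to compound 1 (0.05 log units; that floor lies within the scatter), compound 4 is expected to show a step of an at least 1.0-fold lower number from compound 2 to compound 4 (0.02 log units; that floor lies within the scatter). The estimate for compound 4 in this assay is 95000 nM, with a range from 45000 nM to 250000 nM, and a limit rather than a number is quite possible.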

Compound 4, half-maximal inhibitory concentration: 91700 nM
Compound 4: the middle estimate sits 1.0-fold (0.02 log units) above what was measured; the measured number falls inside the stated range.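

In this assay the same change on the second core gives an at least 1.0-fold lower number from compound 2 to compound 4 (0.03 log units; that floor lies within the scatter), and set beside the first core it reads: the same change on two cores in this assay, an at least 1.1-fold lower number (0.05 log units; that floor lies within the scatter) from compound 3 to compound 1 and an at least 1.0-fold lower number (0.03 log units; that floor lies within the scatter) from compound 2 to compound 4; the limit leaves it open whether they differ. On both cores the floor of the step lies within the scatter, so the change carried from one core to the other shows no clear gain on either, and compound 1 and compound 4 both give numbers where their partners do not. This does not show that the change acts alike on the two cores, nor does it fix the size of either step, since the starting compounds give only a limit and not a number: the limit of > 100000 nM in this assay, at which 2 of the 4 values shown sit.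

The compounds shown leave open whether another group on that amine nitrogen, such as a lone 3-aminopropyl chain, a longer polyamine chain or a carboxylic acid, would move the values on either core. They also leave open whether the two cores would part ways once each starting compound gave a number rather than a limit.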